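Carbamate to ester on an antiproliferative scaffold

A few compounds are considered here, and "the series" means these few. Any claim that something is new, unique, unknown or untested is made for them only; others in the source may bear on it.

Compound 1, `CC1=CC[C@H](C(C)C)c2cc(C)c(OC(=O)Nc3ccccc3)cc21`: 100%
Compound 2, `COc1ccc(C(=O)Oc2cc3c(C)ccc(C(C)C)c3cc2C)cc1`: 42.6%

Compound 1 stands highest of the two numbers in a functional assay on U-251 cells (Homo sapiens) for antiproliferative activity, read by sulforhodamine B assay, with a stated time of 48 h, tested at 50 uM; on this read-out lower numbers stand for less inhibition and higher numbers for more inhibition at the one concentration tested (going by the name of the read-out); compound 2 gives a number that lies well below it, beyond the usual scatter. Compound 3, `CC1=CC[C@H](C(C)C)c2cc(C)c(OC(=O)c3cccc(C)c3)cc21`, is not yet measured. It differs from compound 1 in one place: 3-methylphenyl in place of anilino on a carbonyl carbon. Among the measured compounds shown here, with no step between measured compounds for this change, a moderate downward step is expected from compound 1 to compound 3, since compound 2, also an ester, gives 42.6%. The expected step of a number 25 percentage points lower from compound 1 to compound 3 (beyond the scatter) leaves compound 3 at 75%, within 45% to 100%.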

Compound 3, a percentage reported as inhibition, at one concentration (the size of the read-out at that concentration, not a potency): 16.8%
Beside the measured number, compound 3's estimate is 58.2 percentage points above it; the measured number lies below the stated range.
By their numbers in this assay, from the lowest: compound 3; then compound 2; then compound 1.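

In this assay, putting 3-methylphenyl in place of anilino on the carbonyl carbon gives a number 83.2 percentage points lower from compound 1 to compound 3 (beyond the scatter). This position is therefore sensitive to the change, even though both groups have the same count of heavy atoms and one six-membered aromatic ring, and they differ in that anilino has a hydrogen-bond donor and 3-methylphenyl has none. Nothing available explains the size of this step. Still open, from the compounds shown here alone, is whether the nitrogen with its hydrogen or the ring methyl matters more: a plain phenyl group on the same carbonyl carbon would help separate the two.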